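This account rests on a few compounds, and the source may have more. Where it says the series, first, only, none or still open, it means among the compounds named here.

Measured so far in an ADME assay on PC-3 cells (Homo sapiens) for cytotoxicity, read by WST assay, tested at 100 uM; on this read-out lower numbers stand for less inhibition and higher numbers for more inhibition at the one concentration tested (going by the name of the read-out):
- compound 1 `CSc1cccc(NC(=O)C2CCCN(C(=O)c3cc(C(F)(F)F)cc(C(F)(F)F)c3)C2)c1` — 0%
- compound 2 `O=C(c1ccccc1)c1cccc(NC(=O)C2CCCN(C(=O)c3cc(C(F)(F)F)cc(C(F)(F)F)c3)C2)c1` — 0%
- compound 3 `O=C(Nc1ccc(Cl)cc1)C1CCCN(C(=O)c2cc(C(F)(F)F)cc(C(F)(F)F)c2)C1` — 14%

Compound 3 stands highest of the three numbers; the recorded step is a number 14 percentage points higher from compound 1 to compound 3 (beyond the scatter), and compound 2 sits at the same level as compound 1, so compound 3 is set apart from both beyond the scatter. The two steps recorded so far behave differently: the change on the aromatic carbon gives no change at the digits printed from compound 1 to compound 2 (within the scatter), while the exchange on the amide-type nitrogen gives a number 14 percentage points higher from compound 1 to compound 3 (beyond the scatter).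

The next compound, compound 4 `COc1cccc(NC(=O)C2CCCN(C(=O)c3cc(C(F)(F)F)cc(C(F)(F)F)c3)C2)c1`, differs from compound 3 in one place: 3-methoxyphenyl in place of 4-chlorophenyl on an amide-type nitrogen. Going by the values given here, this is the same site where the only step beyond the scatter was seen, and the group that enters, 3-methoxyphenyl, resembles the 3-(methylsulfanyl)phenyl of compound 1 more than the 4-chlorophenyl of compound 3. Among the compounds with values here, the only bearing step is therefore the one from compound 1 to compound 3, and compound 4 is expected to undo most of it, giving a step of about a number 11 percentage points lower from compound 3 to compound 4 (beyond the scatter), back toward the level of compound 1 and compound 2. In this assay compound 4 is accordingly estimated at 3%, with a range from 0% to 15%.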

Compound 4, a percentage reported as inhibition, at one concentration (the size of the read-out at that concentration, not a potency): 0%
Beside the measured number, compound 4's estimate is 3 percentage points above it; measured number inside the range.
By their numbers in this assay, from the lowest: compounds 1, 2 and 4 (each within the scatter of the next); then compound 3.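

In this assay the amide-type nitrogen now gives a second step beyond the scatter, running opposite to the first: a number 14 percentage points lower from compound 3 to compound 4 (beyond the scatter). The level reached with 4-chlorophenyl is therefore lost when 3-methoxyphenyl enters, while methoxy on the aromatic carbon matches both other groups seen there, with no change at the digits printed from compound 1 to compound 4 (within the scatter) and no change at the digits printed from compound 2 to compound 4 (within the scatter). Among these four compounds, methylsulfanyl, benzoyl and methoxy share one level and compound 3 alone stands apart, but no measurement at hand accounts for this difference.

Since the step from 4-chlorophenyl to 3-methoxyphenyl changes both the substituent and its number in the group name, the compounds shown cannot separate the role of the chlorine from that of its place, and a 3-chlorophenyl or a 4-methoxyphenyl on the same amide-type nitrogen would address this directly. From the compounds shown here alone, it also remains open whether a different kind of substituent on that aryl group, such as an amine or a carboxylic acid, would move the read-out away from the level shared by compound 1, compound 2 and compound 4.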